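Ester in place of acid on the amide-linked phenyl

This account rests on a few compounds, and the source may have more. Where it says the series, first, only, none or still open, it means among the compounds named here.

Measured so far:
- compound 1 `NCc1ccc(C(=O)Nc2ccncc2F)cc1-c1cccc(NC(=O)c2cccc(C(=O)O)c2)c1` — < 1 nM
- compound 2 `NCc1ccc(C(=O)Nc2ccncc2F)cc1-c1cccc(NC(=O)c2ccc(C(=O)O)cc2)c1` — 1 nM

Two compounds of the shared core have been run in an assay on cells for inhibition of Rho-associated protein kinase 2 (Homo sapiens), read by radiometric assay and 33P incorporation, in the presence of a further agent that is not named here; on this read-out lower numbers stand for stronger inhibition and higher numbers for weaker inhibition. For compound 1 the result is a limit of the assay, < 1 nM, not a number. Going by the values given here, compound 2 gives 1 nM in this assay, the only plain number in the set. Among the compounds with values here, the single step, a number no lower from compound 1 to compound 2 (the limit leaves the size open), leaves its size open, since one end is a limit (the limit of < 1 nM in this assay, at which 1 of the 2 values shown sits).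

Compound 3 `COC(=O)c1ccc(F)c(C(=O)Nc2cccc(-c3cc(C(=O)Nc4ccncc4F)ccc3CN)c2)c1` is not yet measured. It differs from compound 2 in one place: 2-fluoro-5-(methoxycarbonyl)phenyl in place of 4-carboxyphenyl on a carbonyl carbon. Within the data shown here, no measured step touches this kind of change; the one step known swaps the position of the carboxylic acid on the same ring and stays within a range that cannot be sized. The change to compound 3 removes the acid and its hydrogen-bond donor and adds a fluorine, so it is expected to move further than the known step, in the direction of weaker inhibition, by a 5.0-fold higher number from compound 2 to compound 3 (0.70 log units; beyond the scatter). Compound 3 is therefore estimated at 5 nM in this assay, with a range from 1 nM to 30 nM.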

Compound 3, half-maximal inhibitory concentration: < 1 nM
Compound 3 ended at the assay's limit (the forecaster's own chance of this, stated with the estimate: 15%); middle value at least 5.0-fold (0.69 log units) from the limit.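

Notes on the group on the carbonyl carbon whose other neighbours are amide-type nitrogen: in this assay, strong inhibition at this place does not depend on a carboxylic acid, since 2-fluoro-5-(methoxycarbonyl)phenyl, which carries no acid, also reaches the bottom of the measurable range. Replacing 4-carboxyphenyl with this group gives a number no higher from compound 2 to compound 3 (the limit leaves the size open), whereas the earlier step only moved the acid around the ring, and the step between compound 1 and compound 3 cannot be read. Compound 3 gives < 1 nM, a limit of the assay and not a number, so this read-out no longer separates the series and no order can be drawn from it: the limit of < 1 nM in this assay, at which 2 of the 3 values shown sit.

As far as these compounds go, the methyl ester and the fluorine enter in one step, so their separate shares in the result stay open, as does how a nitrile or a primary carboxamide would behave at the same place on the ring. From the compounds shown here alone, how far compound 3 and compound 1 lie past the limit also stays open, and telling them apart would take a read-out that resolves values this low.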